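Moving one fluorine: what to expect for compound 3

A few compounds are considered here, and "the series" means these few. Any claim that something is new, unique, unknown or untested is made for them only; others in the source may bear on it.

Compound 1 `O=S(=O)(Nc1cccc(CO)c1)c1ccc(-c2ccc(Br)cc2F)cc1`: 1000 nM
Compound 2 `O=S(=O)(Nc1cccc(CO)c1)c1ccc(-c2ccc(F)cc2)cc1`: 3500 nM

Both values come from a functional assay on J774 cells (Mus musculus) for cytotoxicity, read by resazurin assay, with a stated time of 72 h; on this read-out higher numbers stand for weaker inhibition and lower numbers for stronger inhibition. Of the two measured compounds, compound 2 carries the higher number, 3500 nM, and so shows the weaker inhibition so far.

The next compound to be tested is compound 3 `O=S(=O)(Nc1cccc(CO)c1)c1ccc(-c2ccccc2F)cc1`. It has the same atoms as compound 2, joined differently: 2-fluorophenyl in place of 4-fluorophenyl on an aromatic carbon. The new group, 2-fluorophenyl, takes the place of 4-fluorophenyl on an aromatic carbon, para to a large group.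

Among the compounds with values here, only one measured step bears on this change: a 3.5-fold higher number from compound 1 to compound 2 (0.54 log units; beyond the scatter). That step is modest, and it also involves a bromine that neither compound 2 nor compound 3 carries. No measurement isolates the fluorine change alone, so the evidence is thin.

No change beyond the scatter is therefore expected in this assay, and the direction is left open. The expected result is a 1.2-fold lower number from compound 2 to compound 3 (0.07 log units; within the scatter). For compound 3 the estimated value is 3000 nM, with an expected range of 1300 nM to 7000 nM.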

Compound 3, half-maximal inhibitory concentration: 1300 nM
Beside the measured number, compound 3's estimate is 2.3-fold (0.36 log units) above it; measured number inside the range.
By their numbers in this assay, from the lowest: compounds 1 and 3 (each within the scatter of the next); then compound 2.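

In this assay the shift of one fluorine, with 2-fluorophenyl in place of 4-fluorophenyl, gives a 2.7-fold lower number from compound 2 to compound 3 (0.43 log units; beyond the scatter) on an unchanged set of atoms, so the place of the fluorine on this ring alone moves the number beyond the scatter, towards stronger inhibition. Hydrogen in place of bromo gives a 1.3-fold higher number from compound 1 to compound 3 (0.11 log units; within the scatter) and stays within the scatter, so in this pair the bromine makes no difference that can be told apart, and compound 1 and compound 3, which both carry fluorine as in 2-fluorophenyl, sit together below compound 2. Nothing at hand explains why the place of the fluorine counts here.

Whether the fluorine is needed at all remains open, since the compounds shown do not tell how a plain phenyl, a 2-chlorophenyl or a 2-methoxyphenyl group would read in this assay and whether any of them would stay with compound 3 or with compound 2. Also open, going by these compounds, is whether the same shift of fluorine would give a step of this size if a carboxylic acid or an amine took the place of the hydroxymethyl group.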